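The compounds below may be only part of what the source reports. "The series", "measured", "known", "first", "only" and "open" are said of these compounds alone.

Compound 1 `O=C(Nc1cc(-c2ccccn2)n[nH]1)N1CCC(Oc2ccccn2)CC1` carries a (pyridin-2-yl)oxy group on a saturated ring carbon. In an ADME assay on liver for metabolic stability, with Liver microsome (Homo sapiens) as the target, using microsomes (a lower number here means slower removal, a higher number faster removal of the compound), compound 1 gives < 11.9 mL.min-1.g-1, which is a limit of the assay rather than a number. Compound 1 therefore stands at the limit of < 11.9 mL.min-1.g-1 in this assay, at which 1 of the 3 values shown sits. Compound 3 `O=C(Nc1cc(-c2ccccn2)n[nH]1)N1CCC(c2ccccc2)CC1` gives 15.3 mL.min-1.g-1 in this assay, and compound 2 `COc1ccc(C(=O)Nc2[nH]nc(-c3ccccn3)c2C2CC2)cc1`, a different amide on the shared core, gives 12.8 mL.min-1.g-1. Compound 4 `O=C(Nc1cc(-c2ccccn2)n[nH]1)N1CCC(c2cccc(F)c2)CC1` differs from compound 1 as follows: 3-fluorophenyl in place of (pyridin-2-yl)oxy on a saturated ring carbon. Among the measured compounds shown here, the only measured step that bears on it is an at least 1.2-fold higher number from compound 1 to compound 3 (0.10 log units; that floor lies within the scatter), where phenyl replaces the same group. A comparable small rise, if any, is expected for compound 4 in this assay, to an estimated 14 mL.min-1.g-1 with a range of 8 mL.min-1.g-1 to 25 mL.min-1.g-1. The expected step is an at least 1.1-fold higher number from compound 1 to compound 4 (0.07 log units; that floor lies within the scatter).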

Compound 4, intrinsic clearance in microsomes: 25.3 mL.min-1.g-1
The estimate for compound 4 lay 1.8-fold (0.26 log units) below the measured number; the measured number lies above the stated range.
By their numbers in this assay, from the lowest: compounds 2, 3 and 4 (each within the scatter of the next). At a limit, below all of these: compound 1.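

In this assay, among the compounds shown here, 3-fluorophenyl in place of (pyridin-2-yl)oxy gives an at least 2.1-fold higher number from compound 1 to compound 4 (0.32 log units; beyond the scatter) and is the first step at this saturated ring carbon to clear the scatter. Compound 1 still stands at a limit of the assay and not a number: the limit of < 11.9 mL.min-1.g-1 in this assay, at which 1 of the 4 values shown sits. Fluoro in place of hydrogen on an aromatic carbon gives a 1.7-fold higher number from compound 3 to compound 4 (0.22 log units; within the scatter) and so does not separate compound 3 from compound 4.

Open, going by these compounds, is how far compound 1 truly lies from compound 4. Also open, on these data alone, is whether an amine or a carboxylic acid on this ring carbon would stay close to compound 1.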